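Furan-2-yl in place of 4-hydroxyphenyl on the hydrazone carbon

A few compounds are considered here, and "the series" means these few. Any claim that something is new, unique, unknown or untested is made for them only; others in the source may bear on it.

Three compounds sharing one core have been measured in a functional assay on BGC-823 cells (Homo sapiens) for cytotoxicity, read by MTT assay, with a stated time of 48 h; a lower number here means a stronger inhibitor, a higher number a weaker inhibitor:

Compound 1, `O=C(CSc1nnc(-c2ccncc2)o1)N/N=C/c1ccc(Cl)cc1`: 20500 nM
Compound 2, `O=C(CSc1nnc(-c2ccncc2)o1)N/N=C/c1ccc(O)cc1`: 7940 nM
Compound 3, `Cc1ccc(/C=N/NC(=O)CSc2nnc(-c3ccncc3)o2)cc1`: 21800 nM

Among these three numbers compound 2 stands lowest. Its nearest neighbour is compound 1, the step being a 2.6-fold lower number from compound 1 to compound 2 (0.41 log units; beyond the scatter). Its furthest is compound 3, with a 2.7-fold higher number from compound 2 to compound 3 (0.44 log units; beyond the scatter). Between compound 1 and compound 3 the step is a 1.1-fold higher number from compound 1 to compound 3 (0.03 log units; within the scatter), so these two sit together, and only the hydroxy-bearing compound 2 sets itself apart.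

The next compound, compound 4, `O=C(CSc1nnc(-c2ccncc2)o1)N/N=C/c1ccco1`, has not yet been measured in this assay. Relative to compound 2 the change is furan-2-yl in place of 4-hydroxyphenyl on a carbon with a double bond to nitrogen. Among the measured compounds shown here, no measured step replaces one ring by another at this carbon, so the only guidance comes from the two steps that remove the hydroxy group: from compound 2 to compound 1 and from compound 2 to compound 3, each a modest rise of about the same size. On that basis a modest higher number is expected for compound 4, in the region of the numbers shown for compound 1 and compound 3, with the step from compound 2 estimated as a 2.5-fold higher number from compound 2 to compound 4 (0.40 log units; beyond the scatter). The expected value for compound 4 is 20000 nM, within a range of 8000 nM to 50000 nM.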

Compound 4, half-maximal inhibitory concentration: 25800 nM
Compound 4: the middle estimate sits 1.3-fold (0.11 log units) below what was measured, and the stated range covers the measured number.
By their numbers in this assay, from the lowest: compound 2; then compounds 1, 3 and 4 (each within the scatter of the next).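

In this assay, the step to a five-membered ring at this carbon gives a 3.2-fold higher number from compound 2 to compound 4 (0.51 log units; beyond the scatter), while the comparisons with the other two compounds give a 1.2-fold higher number from compound 3 to compound 4 (0.07 log units; within the scatter) and a 1.3-fold higher number from compound 1 to compound 4 (0.10 log units; within the scatter), both within the scatter. Compound 1, compound 3 and compound 4 therefore form one group, showing that furan-2-yl, 4-chlorophenyl and 4-methylphenyl cannot be told apart here even though the ring itself differs, and that the separation of compound 2 does not depend on keeping a six-membered aromatic ring of carbon only. Among these four compounds, 4-hydroxyphenyl remains the only group at this carbon that carries a hydrogen-bond donor and the only one giving a number set apart from the rest, but no measurement at hand explains this link.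

From the compounds shown here alone, it remains open whether the lower number of compound 2 belongs to the hydroxy group as such, which a 4-methoxyphenyl or 4-aminophenyl group at this carbon could test. Going by these compounds, it is also open whether a hydroxy group carried on the furan-2-yl ring of compound 4 would bring its number towards that of compound 2.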